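Moving a Chlorine Around the Benzyl Ring

This account rests on a few compounds, and the source may have more. Where it says the series, first, only, none or still open, it means among the compounds named here.

Among the compounds with values here, compound 1 `Clc1ccc(COc2ccccc2/C=C/C(/C=C/c2ccccn2)=N/Oc2ncnc3cc(Cl)ccc23)cc1` and compound 2 `Cc1cccc(COc2ccc(/C=C/C(/C=C/c3ccccn3)=N/Oc3ncnc4cccc(C)c34)cc2)c1` are the two compounds measured so far. In a functional assay on SMMC-7721 cells (Homo sapiens) for inhibition, read by MTT assay, with a stated time of 72 h, tested at 10 uM (a lower number here means a weaker effect, a higher number a stronger effect of the compound at the concentration tested), compound 1 gives 94.8% and compound 2 gives 97%, two numbers within the usual scatter of each other, so neither can be called stronger. Compound 3 `Clc1ccc2c(O/N=C(\C=C\c3ccccn3)/C=C/c3ccccc3OCc3ccccc3Cl)ncnc2c1` has not yet been measured. It differs from compound 1 in one place: 2-chlorophenyl in place of 4-chlorophenyl on a saturated chain carbon bound to an oxygen on an aromatic ring. Within the data shown here, no step between measured compounds is known. Because compound 1 already gives 94.8% in this assay, the step of a number 2.8 percentage points lower from compound 1 to compound 3 (within the scatter) is expected to stay within the scatter. Compound 3 is estimated at 92%, within a range from 78% to 99%.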

Compound 3, a percentage reported as inhibition, at one concentration (the size of the read-out at that concentration, not a potency): 94.5%
Compound 3: middle estimate off by 2.5 percentage points, on the low side; the range from low to high includes it.
By their numbers in this assay, from the lowest: compounds 3, 1 and 2 (each within the scatter of the next).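

Moving the chlorine from 4-chlorobenzyl to 2-chlorobenzyl gives, in this assay, a number 0.3 percentage points lower from compound 1 to compound 3 (within the scatter), so at this one test concentration the two placements cannot be told apart. Within the data shown here, this is the first pair that differs in one place only, and it shows that this change on the benzyl ring leaves the read-out in the same range. No measured evidence bears on why this is so. From the compounds shown here alone, whether a methoxy group or an amine on that ring would do the same remains open. A single concentration also leaves open whether compound 1 and compound 3 differ in potency.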